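Aryl hydrazone exchange on the shared core: compound 4

This account rests on a few compounds, and the source may have more. Where it says the series, first, only, none or still open, it means among the compounds named here.

Measured so far:
compound 1 `O=C(N/N=C/c1cccnc1)c1ccc(-c2nc3ccccc3s2)cc1` — "not active" (no number reported)
compound 2 `O=C(N/N=C/c1ccc(O)cc1)c1ccc(-c2nc3ccccc3s2)cc1` — 11300 nM
compound 3 `O=C(N/N=C/c1cccs1)c1ccc(-c2nc3ccccc3s2)cc1` — 8480 nM

In an assay on isolated protein for inhibition of Maltase-glucoamylase (Homo sapiens), with a stated time of 15 min (on this read-out lower numbers stand for stronger inhibition and higher numbers for weaker inhibition), compound 1 was reported as "not active" (no number reported) and no number was given. Compound 2 gives 11300 nM and compound 3 gives 8480 nM; compound 3 sits alongside compound 2, the step of a 1.3-fold lower number from compound 2 to compound 3 (0.12 log units; within the scatter) being within the scatter. Compound 4 `COc1ccc(/C=N/NC(=O)c2ccc(-c3nc4ccccc4s3)cc2)c(O)c1` is not yet measured; it differs from compound 3 by 2-hydroxy-4-methoxyphenyl in place of thiophen-2-yl on a carbon with a double bond to nitrogen. Within the data shown here, the only step that bears on exchanging the aryl group on this carbon is that from compound 2 to compound 3, and it was small. The entering group carries a hydroxy as the 4-hydroxyphenyl of compound 2 does, and compound 2 gives 11300 nM, so no step beyond the scatter is expected, a 1.2-fold lower number from compound 3 to compound 4 (0.08 log units; within the scatter). Compound 4 is therefore estimated at 7000 nM, range 2500 nM to 25000 nM.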

Compound 4, half-maximal inhibitory concentration: 6970 nM
For compound 4 the middle estimate is 1.0-fold (0.00 log units) above the measured one, and the stated range covers the measured number.
By their numbers in this assay, from the lowest: compounds 4, 3 and 2 (each within the scatter of the next).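

This position takes 2-hydroxy-4-methoxyphenyl with a 1.2-fold lower number from compound 3 to compound 4 (0.09 log units; within the scatter) against thiophen-2-yl and with a 1.6-fold lower number from compound 2 to compound 4 (0.21 log units; within the scatter) against 4-hydroxyphenyl. Compound 2, compound 3 and compound 4 therefore all lie within the scatter of one another, whether the group on this carbon is a five-membered ring with sulfur or a six-membered carbon ring bearing hydroxy, with or without methoxy. Only compound 1 stands apart, reported as "not active" (no number reported) in this series. Going by these compounds, whether an amine or a carboxylic acid on this aryl group would give a step beyond the scatter remains open. No supporting data bear on this result.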